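This account rests on a few compounds, and the source may have more. Where it says the series, first, only, none or still open, it means among the compounds named here.

Series notes, cytotoxicity in an ADME assay on MT4 cells (Homo sapiens) for cytotoxicity, read by MTT assay, with a stated time of 4 days; a lower number here means that less compound is tolerated, a higher number that more compound is tolerated:

- compound 1 `CC(=O)Nc1ccc(O)c(C(=O)/C=C/c2cccc(F)c2)c1` gives 30100 nM
- compound 2 `CC(=O)Nc1ccc(O)c(C(=O)/C=C/c2cccc(C(F)(F)F)c2)c1` gives 32100 nM
- compound 3 `COc1c(-c2cccc(F)c2)oc2ccc(NC(C)=O)cc2c1=O` gives 210000 nM

Compound 1 and compound 2 share a core and differ only in one place: trifluoromethyl in place of fluoro on an aromatic carbon. The step in this assay is a 1.1-fold higher number from compound 1 to compound 2 (0.03 log units; within the scatter).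

Compound 3 carries a different core; how the core of compound 3 differs from the core of compound 1 is not broken down here. In this assay compound 3 stands highest of the three, beyond the scatter from both compound 1 and compound 2.

Compound 4 `COc1c(-c2cccc(C(F)(F)F)c2)oc2ccc(NC(C)=O)cc2c1=O` is not yet measured. It differs from compound 3 by trifluoromethyl in place of fluoro on an aromatic carbon, the same change, at the same kind of place, as from compound 1 to compound 2.

Compound 4 is expected to sit close to compound 3, because the same change gave a 1.1-fold higher number from compound 1 to compound 2 (0.03 log units; within the scatter). The estimated step is a 1.1-fold higher number from compound 3 to compound 4 (0.04 log units; within the scatter). For compound 4 the estimate in this assay is 230000 nM, expected between 110000 nM and 450000 nM.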

Compound 4, half-maximal cytotoxic concentration: 201000 nM
Compound 4: the middle estimate sits 1.1-fold (0.06 log units) above what was measured; the range from low to high includes it.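

Notes on the change from fluoro to trifluoromethyl in this assay: on the core of compound 3 the step is a 1.0-fold lower number from compound 3 to compound 4 (0.02 log units; within the scatter). The two steps on the two cores agree: the same change on two cores in this assay, a 1.1-fold higher number (0.03 log units; within the scatter) from compound 1 to compound 2 and a 1.0-fold lower number (0.02 log units; within the scatter) from compound 3 to compound 4, 1.1-fold (0.05 log units) apart, within the scatter of two such steps. Among these compounds, this shows that the change carries over between these two cores without a detectable difference, but with only two pairs, both at the same kind of place and both within the scatter, it does not show that the same would hold on any other core or at any other place.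

Still open, going by these compounds, is how a different group on that aromatic carbon, such as an amine or a carboxylic acid, would read in this assay. Also open is which part of the core of compound 3 accounts for its standing above compound 1 and compound 2.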